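Amide Replacement by a Thioamide in a Tetrazole Series

A few compounds are considered here, and "the series" means these few. Any claim that something is new, unique, unknown or untested is made for them only; others in the source may bear on it.

Measured compounds:
compound 1, `CCCCc1nc(C)c(CC(=O)N(C)C)c(=O)n1Cc1ccc(-c2ccccc2-c2nnn[nH]2)cc1` — 0.018 mg/kg
compound 2, `CCCCc1nc(C)c(CC(=O)N2CC(C)OC(C)C2)c(=O)n1Cc1ccc(-c2ccccc2-c2nnn[nH]2)cc1` — 0.029 mg/kg

Both compounds were tested in an in vivo functional assay on the whole organism for inhibition, with Rattus norvegicus as the target; on this read-out higher numbers stand for an effect only at larger amounts of compound and lower numbers for an effect already at smaller amounts. In this assay compound 1 gives 0.018 mg/kg and compound 2 gives 0.029 mg/kg. Going by the values given here, compound 2 has the highest of the two numbers, but the single step, a 1.6-fold higher number from compound 1 to compound 2 (0.21 log units; within the scatter), is within the scatter, so the two compounds cannot be told apart on these figures.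

Compound 3, `CCCCc1nc(C)c(CC(=S)N2CCCCCC2)c(=O)n1Cc1ccc(-c2ccccc2-c2nnn[nH]2)cc1`, has not been measured. It differs from compound 2 in the following way: a group of 9 heavy atoms (7 carbon, 1 nitrogen, 1 sulfur; one seven-membered non-aromatic ring with 1 hetero atom) in place of a group of 10 heavy atoms (7 carbon, 1 nitrogen, 2 oxygen; one six-membered non-aromatic ring with 2 hetero atoms), on a saturated chain carbon bound to an aromatic carbon. Among the compounds with values here, the only measured step, from compound 1 to compound 2, exchanged one amide substituent for another and stayed within the scatter. Within the data shown here, the step to compound 3 also exchanges the ring on the nitrogen, but it additionally turns the carbonyl into a thiocarbonyl, a change no measured pair covers. Because a 1.6-fold higher number from compound 1 to compound 2 (0.21 log units; within the scatter) was within the scatter, compound 3 is expected to stay near compound 2, with a step of about a 1.4-fold higher number from compound 2 to compound 3 (0.14 log units; within the scatter) and considerable uncertainty. Compound 3 is therefore estimated at 0.04 mg/kg, within a range of 0.012 mg/kg to 0.15 mg/kg.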

Compound 3, dose for half-maximal effect: 0.034 mg/kg
Estimate against measurement, compound 3: 1.2-fold (0.07 log units) above; the range from low to high includes it.
By their numbers in this assay, from the lowest: compounds 1, 2 and 3 (each within the scatter of the next).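

Compound 3 brings a change at this place that the earlier pair did not cover: a thiocarbonyl in place of the carbonyl, carrying a seven-membered ring on the nitrogen. In this assay, this gives a 1.2-fold higher number from compound 2 to compound 3 (0.07 log units; within the scatter), and against the dimethylamino amide it gives a 1.9-fold higher number from compound 1 to compound 3 (0.28 log units; within the scatter), so neither step separates compound 3 from the two amides. Within these three compounds, then, the group on this saturated chain carbon bound to an aromatic carbon can carry sulfur in place of the carbonyl oxygen and a larger ring on the nitrogen with no change that can be told from scatter, though nothing shown here offers an explanation for this.

The exchange of oxygen for sulfur and the exchange of the ring arrive together in compound 3, so the share of each stays unresolved; the dimethylamino thioamide, or the amide carrying the seven-membered ring, would pull them apart. Also open, from the compounds shown here alone, is whether the read-out stays this flat with a carboxylic acid or a primary amine at the end of this chain, in place of the substituted amide.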